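The compounds below may be only part of what the source reports. "The series", "measured", "known", "first", "only" and "open" are said of these compounds alone.

In a functional assay, with a stated time of 150 min (on this read-out higher numbers stand for weaker inhibition and lower numbers for stronger inhibition), three compounds have been measured. Compound 1 `COc1ccc(-c2nc(SC)n(C)c(=O)c2C#N)cc1` gives 73 ug/mL. Compound 3 `CSc1nc(-c2cccs2)c(C#N)c(=O)n1C`, which contains a thiophen-2-yl group, gives 87 ug/mL. Compound 2 `CCOC(=O)c1cnn(-c2nc(-c3cccc(OC)c3OC)c(C#N)c(=O)n2C)c1N` gives 69 ug/mL, the lowest of the three numbers; its distances to compound 1 and to compound 3, however, both fall within the scatter of repeated measurements, so none of the three can be called stronger or weaker than the others.

Compound 4 `CCOC(=O)c1cnn(-c2nc(-c3cccs3)c(C#N)c(=O)n2C)c1N` has not yet been measured. It differs from compound 2 in one place: thiophen-2-yl in place of 2,3-dimethoxyphenyl on an aromatic carbon. Within the data shown here, no measured pair here differs in exactly this way, so the size of this step cannot be read off directly. The only related hint comes from compound 3, which carries a thiophen-2-yl group and gives 87 ug/mL, set against compound 1, which carries none and gives 73 ug/mL. These two values lie within the scatter of each other. For this change the expected step is a 1.1-fold higher number from compound 2 to compound 4 (0.04 log units; within the scatter), which amounts to nothing beyond the scatter in either direction. Compound 4 is therefore estimated to give about 75 ug/mL, with a likely range from 45 ug/mL to 125 ug/mL.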

Compound 4, half-maximal inhibitory concentration: 98 ug/mL
Estimate against measurement, compound 4: 1.3-fold (0.12 log units) below; low and high end bracket the measured number.
By their numbers in this assay, from the lowest: compounds 2, 1, 3 and 4 (each within the scatter of the next).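

In this assay, among these compounds, the step of a 1.4-fold higher number from compound 2 to compound 4 (0.15 log units; within the scatter) is the first direct reading of this change at this position, with the rest of the molecule held constant. Thiophen-2-yl is a five-membered aromatic ring with one sulfur atom, whereas 2,3-dimethoxyphenyl is a six-membered aromatic ring of carbon only with two hydrogen-bond acceptors, yet this step does not separate the two compounds beyond the usual scatter, so at this position the read-out does not distinguish between these two aromatic groups. Nothing measured here speaks to why the step has this size.

From the compounds shown here alone, what a non-aromatic group would do on this same aromatic carbon remains open, whether an amine, a carboxylic acid or a longer alkyl chain. Since these two aromatic groups give numbers within the scatter of each other, they do not show how far this position can move the read-out in either direction, or whether any replacement here would produce a step beyond the scatter.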